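The source may hold more compounds than are shown below. What is called first, only, known or untested is meant among the compounds shown, and "the series" means these compounds.

Within the data shown here, in a physicochemical assay for lipophilicity, measured as octanol-water partition (on this read-out lower numbers stand for lower lipophilicity and higher numbers for higher lipophilicity), compound 1 `CCO/N=C/Nc1cc(Cl)c(O)c(Cl)c1` gives 2.8, while compound 2 `CCCOc1c(Cl)cc(N/C=N/OCC)cc1Cl` gives 4.6, the highest of the two numbers so far. Among the measured compounds shown here, the only measured step is a number 1.80 log units higher from compound 1 to compound 2 (beyond the scatter), and it comes with propyl in place of hydrogen on an oxygen on an aromatic ring.

Compound 3 `CC#CCOc1c(Cl)cc(N/C=N/OCC)cc1Cl` has not yet been measured. Its difference from compound 2 is prop-1-yn-1-yl in place of ethyl on a saturated chain carbon bound to an oxygen on an aromatic ring. The same change can be read as propyl to but-2-yn-1-yl.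

The measured step bears on this only loosely. It replaced a hydrogen on the oxygen, whereas compound 3 keeps a chain there and exchanges only part of it. For the measured compounds named here, no measured compound carries a triple bond, so the data do not test this change directly. A step of the earlier size is therefore not expected in this assay, and the expectation is for little change, leaning slightly downward. The estimated step is a number 0.20 log units lower from compound 2 to compound 3 (within the scatter). Compound 3 is expected at 4.4, within an estimated range of 4 to 4.8.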

Compound 3, partition coefficient: 4
For compound 3 the middle estimate is 0.40 log units above the measured one; the range from low to high includes it.
By their numbers in this assay, from the lowest: compound 1; then compound 3; then compound 2.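

In this assay, the chain on this oxygen proves sensitive to more than its presence: prop-1-yn-1-yl in place of ethyl on a saturated chain carbon bound to an oxygen on an aromatic ring gives a number 0.60 log units lower from compound 2 to compound 3 (beyond the scatter), even though the entering group holds 3 carbon against the 2 of the group that leaves. The chain that carries the triple bond nevertheless keeps much of the rise seen with propyl, as but-2-yn-1-yl in place of hydrogen on the oxygen gives a number 1.20 log units higher from compound 1 to compound 3 (beyond the scatter), while propyl in the same place gives a number 1.80 log units higher from compound 1 to compound 2 (beyond the scatter), so among these three compounds both chains stand above the free hydrogen and propyl stands highest. The data given here offer no independent measurement that would account for the gap between these two chains.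

The compounds shown leave open whether the gap follows the triple bond itself or the particular chain, a question that a saturated butyl chain on the same oxygen would bear on directly. They also leave open how this position would respond to a chain ending in an amine or a carboxylic acid.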